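The source may report more compounds than this note shows. Statements on the series, on what has been measured and on what is new or still open speak of the compounds shown alone.

Working notes on the alkoxy chain of the series. In an ADME assay on RAW264.7 cells (Mus musculus) for cytotoxicity, read by MTT assay, with a stated time of 24 h, in the presence of a further agent that is not named here (a lower number here means a stronger inhibitor, a higher number a weaker inhibitor), compound 1 (`CCCCOc1ccc(C(O)C2OC(=O)c3c(OC)cc(OC)cc32)cc1`) gives > 40000 nM as a limit of the assay. Compound 2 (`CCC(C)Oc1ccc(C(O)C2OC(=O)c3c(OC)cc(OC)cc32)cc1`) gives > 40000 nM as a limit too. Compound 3 (`COCCCOc1ccc(C(O)C2OC(=O)c3c(OC)cc(OC)cc32)cc1`) gives > 40000 nM as a limit as well, so it has no number of its own. Its standing is shared with the other two, as the limit of > 40000 nM in this assay, at which 3 of the 3 values shown sit, shows.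

Compound 4 (`CCOCCOc1ccc(C(O)C2OC(=O)c3c(OC)cc(OC)cc32)cc1`) has the same atoms as compound 3, joined differently, as ethoxy in place of methoxymethyl on a saturated chain carbon, two bonds along the chain from an oxygen on an aromatic ring counts. In words, this is ethoxy in place of methoxymethyl on a saturated chain carbon, two bonds along the chain from an oxygen on an aromatic ring, which turns 3-methoxypropyl into 2-ethoxyethyl.

The measured steps that bear on this change are swaps in the same chain. They are a step that the two limits leave unreadable from compound 1 to compound 2 and a step that the two limits leave unreadable from compound 1 to compound 3 and also a step that the two limits leave unreadable from compound 2 to compound 3 in the same terms. None of them gives a size to carry over, so no step beyond the scatter is expected in this assay and no direction can be assigned. The expected change is a step that the limit leaves unreadable from compound 3 to compound 4 with no real shift anticipated. Compound 4 is estimated at 50000 nM with an expected range of 25000 nM to 100000 nM and is most likely to be reported as a limit again.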

Compound 4, half-maximal inhibitory concentration: > 40000 nM
Compound 4: only a limit was reported; the forecaster's own chance of this, stated with the estimate: 85%; the middle value lies beyond the limit too.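

In this assay compound 4 is again reported as a limit, like compound 1, compound 2 and compound 3, and no step among these four compounds can be read: the limit of > 40000 nM in this assay, at which 4 of the 4 values shown sit. The compounds shown leave open whether any of these alkoxy chains shifts the half-maximal inhibitory concentration at all, as none of them has a number of its own.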